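Swapping the pyrazole of compound 1 for an oxazole

This account rests on a few compounds, and the source may have more. Where it says the series, first, only, none or still open, it means among the compounds named here.

Compound 1 `COc1ccc(/C=C/c2cc(C)n[nH]2)cc1OC` stands at the top of the three numbers measured in an ADME assay on NIH3T3 cells (Mus musculus) for cytotoxicity, read by MTT assay, with a stated time of 72 h (on this read-out higher numbers stand for weaker inhibition and lower numbers for stronger inhibition), where compound 1 gives 68400 nM. Compound 2 `COc1ccc(/C=C/c2cc(C)n[nH]2)cc1` gives 19900 nM in this assay, and compound 3 `Cc1cc(/C=C/c2ccc(O)c(O)c2)on1` gives 26200 nM. Among the measured compounds shown here, the single step between measured compounds that differ in one place, hydrogen in place of methoxy on an aromatic carbon, is a 3.4-fold lower number from compound 1 to compound 2 (0.54 log units; beyond the scatter), a change of modest size.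

Compound 4 `COc1ccc(/C=C/c2cc(C)no2)cc1OC` differs from compound 1 by 3-methyl-1,2-oxazol-5-yl in place of 3-methyl-1H-pyrazol-5-yl on a double-bonded chain carbon bound to a double-bonded chain carbon. For the measured compounds named here, no measured step alters the same part of the shared core, so none bears directly on this change. Compound 3 carries the same 3-methyl-1,2-oxazol-5-yl group but differs from compound 4 in more than one place, and its value only shows that such a compound can land somewhat lower than compound 1. Going by the values given here, the one measured step shows that a small change at the periphery can move this read-out beyond the scatter, so the expected step is a 1.7-fold lower number from compound 1 to compound 4 (0.23 log units; within the scatter), towards a lower number but of uncertain size. For compound 4 the estimate in this assay is 40000 nM, expected to fall between 15000 nM and 100000 nM.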

Compound 4, half-maximal inhibitory concentration: 93200 nM
Compound 4: the middle estimate sits 2.3-fold (0.37 log units) below what was measured, within the range that was stated.
By their numbers in this assay, from the lowest: compounds 2 and 3 (each within the scatter of the next); then compounds 1 and 4 (each within the scatter of the next).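

In this assay, putting 3-methyl-1,2-oxazol-5-yl in place of 3-methyl-1H-pyrazol-5-yl gives a 1.4-fold higher number from compound 1 to compound 4 (0.13 log units; within the scatter), the first step read at this place on a double-bonded chain carbon bound to a double-bonded chain carbon. Among the compounds shown here, the only earlier step, a 3.4-fold lower number from compound 1 to compound 2 (0.54 log units; beyond the scatter), concerned a methoxy group on an aromatic carbon, whereas this exchange, in which 1 hydrogen-bond donor gives way to 0, cannot be told from the scatter on this read-out. Nothing at hand explains this outcome.

The compounds shown leave open whether the same exchange would read alike on the core of compound 2, which lacks that methoxy group. They also leave open how this read-out would respond to an amine or a carboxylic acid in this place.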